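The source may hold more compounds than are shown below. What is called first, only, known or untested is meant among the compounds shown, and "the series" means these compounds.

Working notes on the series. The shared core carries a varied group on an aromatic carbon of the six-membered aromatic ring with two nitrogens. Compound 1 `Cc1cnc(-c2nn(Cc3ccccc3F)c3ncccc23)nc1N` bears methyl there and gives 675000 nM in a functional assay (aorta) with Oryctolagus cuniculus as the target; on this read-out lower numbers stand for stronger inhibition and higher numbers for weaker inhibition. Compound 2 `Nc1nc(-c2nn(Cc3ccccc3F)c3ncccc23)ncc1C1CCCCC1` bears cyclohexyl and gives 561000 nM in this assay. Going by the values given here, the single measured step, a 1.2-fold lower number from compound 1 to compound 2 (0.08 log units; within the scatter), does not separate the two; the numbers of compound 2 and compound 1 sit within the usual scatter of each other, so no standing of compound 2 relative to compound 1 can be read from them.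

Compound 3 `Nc1nc(-c2nn(Cc3ccccc3F)c3ncccc23)ncc1CC(F)(F)F` is not yet measured. The change from compound 2 is 2,2,2-trifluoroethyl in place of cyclohexyl on an aromatic carbon. Among the compounds with values here, only the step from compound 1 to compound 2 bears on it, and that step was within the scatter; a change from methyl to cyclohexyl at this position left the number as it was. On that basis a step no larger than the scatter is expected for compound 3, with no direction to favour, so a 1.1-fold higher number from compound 2 to compound 3 (0.03 log units; within the scatter) is the expected step. Compound 3 is therefore estimated at 600000 nM, in the range 250000 nM to 1500000 nM.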

Compound 3, half-maximal inhibitory concentration: 508000 nM
Compound 3: middle estimate off by 1.2-fold (0.07 log units), on the high side, and the stated range covers the measured number.
By their numbers in this assay, from the lowest: compounds 3, 2 and 1 (each within the scatter of the next).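

In this assay the exchange of cyclohexyl for 2,2,2-trifluoroethyl gives a 1.1-fold lower number from compound 2 to compound 3 (0.04 log units; within the scatter) and so does not separate a six-membered non-aromatic ring of carbon only from an open chain carrying fluorine at this position, on an aromatic carbon ortho to an amino group. Trifluoromethyl in place of hydrogen on the saturated chain carbon bound to this aromatic carbon gives a 1.3-fold lower number from compound 1 to compound 3 (0.12 log units; within the scatter) and likewise leaves the two compounds inseparable, which extends the flat picture from the carbon-only groups of compound 1 and compound 2 to a group bearing fluorine, with none of the three compounds going against it. No measurement is available that bears on this flat result.

Still open is whether any group at this position moves the number beyond the scatter, since all three groups shown have no hydrogen-bond donors, no hydrogen-bond acceptors and no net charge. An amine, a hydroxyl, a carboxylic acid or a phenyl ring here would test that, as would plain hydrogen in place of the group.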